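Methoxy for fluoro on the N-aryl ring of compound 2

This account rests on a few compounds, and the source may have more. Where it says the series, first, only, none or still open, it means among the compounds named here.

Compound 1 `O=C(Nc1ccc(Oc2ccnc3[nH]ccc23)cc1)c1cc2cccnc2n(-c2ccc(F)cc2)c1=O` and compound 2 `O=C(Nc1ccc(Oc2ccnc3[nH]ccc23)c(F)c1)c1cc2cccnc2n(-c2ccc(F)cc2)c1=O` share the same core and differ only by a fluoro in place of hydrogen on an aromatic carbon. In a functional assay on A549 cells (Homo sapiens) for antiproliferative activity, read by MTT assay, with a stated time of 72 h (a higher number here means a weaker inhibitor, a lower number a stronger inhibitor), compound 1 gives 210 nM, and compound 2 gives 62 nM; the step of a 3.4-fold lower number from compound 1 to compound 2 (0.53 log units; beyond the scatter) is the only one measured, and on these two numbers compound 2 stands lowest.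

Compound 3 `COc1ccc(-n2c(=O)c(C(=O)Nc3ccc(Oc4ccnc5[nH]ccc45)c(F)c3)cc3cccnc32)cc1` departs from compound 2 by methoxy in place of fluoro on an aromatic carbon; seen one bond further out, 4-fluorophenyl becomes 4-methoxyphenyl. For the measured compounds named here, no measured step touches this ring: the step from compound 1 to compound 2 changed the other six-membered ring, so it says nothing about the effect of a methoxy here. Going by the values given here, with no comparable precedent, the change is expected to stay within the scatter, and the estimated step of a 1.3-fold higher number from compound 2 to compound 3 (0.11 log units; within the scatter) is accordingly small. Compound 3 is therefore expected to give about 80 nM, with a range from 25 nM to 250 nM.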

Compound 3, half-maximal inhibitory concentration: 610 nM
The estimate for compound 3 lay 7.6-fold (0.88 log units) below the measured number, outside the stated range (above it).
By their numbers in this assay, from the lowest: compound 2; then compound 1; then compound 3.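

In this assay, the aromatic carbon para to a large group proves sensitive to its substituent: the exchange of fluoro for methoxy gives a 9.8-fold higher number from compound 2 to compound 3 (0.99 log units; beyond the scatter). The earlier step, a 3.4-fold lower number from compound 1 to compound 2 (0.53 log units; beyond the scatter), was made on the other six-membered ring and gave no reading of this position, whereas compound 2 and compound 3 differ only here, so this step belongs entirely to the 4-fluorophenyl to 4-methoxyphenyl exchange. No measurement available for this pair gives a reason for the step, so the result stands as an observation on potency alone.

On these data alone, with only fluoro and methoxy at this carbon, the pair cannot tell whether fluoro favours antiproliferative activity, methoxy disfavours it, or both contribute, and the position of hydrogen, chloro, methyl, ethoxy or a dimethylamino group relative to compound 2 and compound 3 remains open. Also open, as far as these compounds go, is whether the same exchange would give a step of similar size without the fluoro on the other ring, the setting of compound 1.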